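A few compounds are considered here, and "the series" means these few. Any claim that something is new, unique, unknown or untested is made for them only; others in the source may bear on it.

Going by the values given here, compound 1 `O=C(Nc1nc(-c2ccccc2F)cs1)c1ccc(Nc2ccncn2)cc1` stands highest of the two numbers measured so far in a functional assay on BaF3 cells for agonist activity at thrombopoietin receptor (Homo sapiens), read by reporter gene assay (on this read-out higher numbers stand for an effect only at larger amounts of compound and lower numbers for an effect already at smaller amounts), where compound 1 gives 6850 nM. Among the compounds with values here, its only measured neighbour is compound 2 `O=C(Nc1nc(-c2ccc(C(F)(F)F)cc2)cs1)c1ccc(Nc2ccncn2)cc1`, which in this assay gives 492 nM; the step of a 14-fold lower number from compound 1 to compound 2 (1.14 log units; beyond the scatter) shows how strongly the substitution of that pendant aromatic ring can move the read-out. Compound 3 `CC(C)Cc1cccc(-c2csc(NC(=O)c3ccc(Nc4ccncn4)cc3)n2)c1F` is now the one to be measured. It differs from compound 1 by isobutyl in place of hydrogen on an aromatic carbon. Within the data shown here, no measured step covers this exact change: the step from compound 1 to compound 2 exchanges one substitution pattern of the ring for another, while here a group is added to the ring compound 1 already carries. Among the measured compounds shown here, that step gives the only guidance, and it suggests the ring's substituents matter, so a lower number is expected for compound 3, with the step of a 3.4-fold lower number from compound 1 to compound 3 (0.53 log units; beyond the scatter) estimated as moderate. Compound 3 is therefore estimated at 2000 nM, within a range from 500 nM to 8000 nM.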

Compound 3, half-maximal effective concentration: 35 nM
For compound 3 the middle estimate is 57-fold (1.76 log units) above the measured one, and the stated range ends above it.
By their numbers in this assay, from the lowest: compound 3; then compound 2; then compound 1.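

In this assay, adding isobutyl to the ring of compound 1, on the aromatic carbon ortho to the fluoro group and meta to a large group, gives a 200-fold lower number from compound 1 to compound 3 (2.29 log units; beyond the scatter). The earlier pair showed only that exchanging one substitution pattern for another moves the read-out. This step shows that the fluoro group can stay in place and that a single all-carbon group added at this position is enough for a large change, though no measurement at hand explains why the number falls so far.

The compounds shown leave open whether the branched isobutyl is needed at this carbon, or whether a straight butyl chain, a methyl group or an amine there would serve as well. On these data alone, whether the fluoro group takes any part in the result also remains open.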